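The compounds below may be only part of what the source reports. "The series", "measured", "known", "first", "only" and "open" are said of these compounds alone.

Working notes on the anilino series. Compound 1 `COc1cc(Nc2nc(SCc3ccc(C(F)(F)F)cc3)nc3ccccc23)cc(OC)c1` carries a 3,5-dimethoxyphenyl on the ring nitrogen; in a functional assay on PC-3 cells (Homo sapiens) for cytotoxicity, read by MTT assay, with a stated time of 72 h (on this read-out higher numbers stand for weaker inhibition and lower numbers for stronger inhibition), compound 1 reaches only a limit of the assay, > 50000 nM. Compound 2 `COc1ccc(Nc2nc(SCc3ccc(C(F)(F)F)cc3)nc3ccccc23)cc1OC` carries the 3,4-dimethoxyphenyl instead, and in this assay compound 2 gives 14100 nM. Among the compounds with values here, that is the only number recorded; the other value is a limit, so compound 2 stands alone as the sole measured potency. Within the data shown here, the step of an at least 3.5-fold lower number from compound 1 to compound 2 (0.54 log units; beyond the scatter) is the one measured change, read against (the limit of > 50000 nM in this assay, at which 1 of the 2 values shown sits).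

Compound 3 `COc1cc(Nc2nc(SCc3ccc(C(F)(F)F)cc3)nc3ccccc23)cc(OC)c1OC` is the next step: methoxy in place of hydrogen on an aromatic carbon, giving a trimethoxyphenyl that joins the substitution of compound 1 with that of compound 2. Among the measured compounds shown here, only the step from compound 1 to compound 2 bears on this, and it only sets a floor, so the direction of the added methoxy is not settled by the data. A step of a 1.6-fold higher number from compound 2 to compound 3 (0.19 log units; within the scatter) in this assay is expected, leaning toward a weaker result. Compound 3 is therefore estimated at 22000 nM, with a range from 7000 nM to 60000 nM in this assay.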

Compound 3, half-maximal inhibitory concentration: 7370 nM
Beside the measured number, compound 3's estimate is 3.0-fold (0.47 log units) above it; the measured number falls inside the stated range.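

On the 3,4-dimethoxyphenyl, a methoxy on the aromatic carbon ortho to a methoxy group and meta to a large group gives a 1.9-fold lower number from compound 2 to compound 3 (0.28 log units; within the scatter) in this assay, so compound 2 and compound 3 cannot be told apart and this carbon tolerates the added methoxy without a readable change. The 3,5-dimethoxyphenyl responds differently: a methoxy added there, at a different place on the ring, gives an at least 6.7-fold lower number from compound 1 to compound 3 (0.83 log units; beyond the scatter), so the trimethoxyphenyl of compound 3 separates from compound 1 while staying level with compound 2, and the arrangement of the methoxy groups counts for more than their number. Compound 1 stands at a limit of the assay, and this step is therefore only a floor: the limit of > 50000 nM in this assay, at which 1 of the 3 values shown sits.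

From the compounds shown here alone, whether the methoxy group itself is needed at this carbon stays open, as a hydroxyl, a fluorine or an amine there would be required to separate that group from any other substituent. The compounds shown also leave open how far the ring can be changed in other ways, for instance with an ethoxy group or a carboxylic acid in place of a methoxy.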